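A few compounds are considered here, and "the series" means these few. Any claim that something is new, unique, unknown or untested is made for them only; others in the source may bear on it.

Going by the values given here, in a physicochemical assay for solubility, read by nephelometry, measured as kinetic solubility, at pH 2.0 (a higher number here means a more soluble compound, a lower number a less soluble compound), compound 1, `CC(C)(C)c1cc(C(=O)Nc2ccccn2)n(Cc2ccccc2)n1`, gives 25 ug/mL, the only true number among the values shown. Compound 2, `NCc1csc(NC(=O)c2ccn[nH]2)n1`, reaches only a limit of the assay, > 100 ug/mL. Compound 3, `NCc1csc(NC(=O)c2cc3ccccc3[nH]2)n1`, likewise gives only a limit, > 100 ug/mL. Compound 4, `CC(C)(C)c1cc(C(=O)Nc2nc(CO)cs2)n(Cc2ccccc2)n1`, carries 4-(hydroxymethyl)-1,3-thiazol-2-yl in place of pyridin-2-yl on the amide-type nitrogen of compound 1 (4-(hydroxymethyl)-1,3-thiazol-2-yl in place of pyridin-2-yl on an amide-type nitrogen). Among the compounds with values here, no measured pair shows this change, so only a small rise in this assay, close to the scatter, is expected, with compound 2 and compound 3 resting at the limit of > 100 ug/mL in this assay, at which 2 of the 3 values shown sit, but otherwise far from compound 1. The expected step is a 1.6-fold higher number from compound 1 to compound 4 (0.20 log units; within the scatter). Compound 4 is estimated at 40 ug/mL, with an expected range of 15 ug/mL to 100 ug/mL.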

Compound 4, solubility: 12.5 ug/mL
The estimate for compound 4 lay 3.2-fold (0.51 log units) above the measured number; the measured number lies below the stated range.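

In this assay, 4-(hydroxymethyl)-1,3-thiazol-2-yl in place of pyridin-2-yl on the amide-type nitrogen gives a 2.0-fold lower number from compound 1 to compound 4 (0.30 log units; within the scatter). Going by these compounds alone, this is the first step read at this position, and it shows that one more hydrogen-bond donor and two more hydrogen-bond acceptors in this group do not take the reading beyond the scatter. Nothing shown accounts for this step. The compounds shown do not separate the change of ring from the hydroxymethyl group. As far as these compounds go, whether an amine or a carboxylic acid in its place would move the reading beyond the scatter remains open.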